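A few compounds are considered here, and "the series" means these few. Any claim that something is new, unique, unknown or untested is made for them only; others in the source may bear on it.

In a functional assay on MCF7 cells (Homo sapiens) for antiproliferative activity, read by MTT assay, with a stated time of 72 h (on this read-out lower numbers stand for stronger inhibition and higher numbers for weaker inhibition), the series sits near the top of the measurable window. Compound 1 `COc1cc(-c2ncnn2-c2ccccc2)cc(OC)c1OC` returns only a limit, > 10000 nM. Compound 2 `COc1ccc(-n2ncnc2-c2cc(OC)c(OC)c(OC)c2)cc1` gives a number, 7400 nM. Compound 3 `COc1cc(-c2ncnn2-c2ccc(Cl)cc2Cl)cc(OC)c1OC` again returns only a limit, > 10000 nM. Compound 3 thus stands at the limit noted in the limit of > 10000 nM in this assay, at which 2 of the 3 values shown sit, where two of the three values rest. The step of an at least 1.3-fold higher number from compound 2 to compound 3 (0.13 log units; that floor lies within the scatter) is bounded on one side only, and the step that the two limits leave unreadable from compound 1 to compound 3 cannot be sized at all.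

Compound 4 `COc1cc(-c2ncnn2-c2ccc(F)cc2)cc(OC)c1OC` carries the change (4-fluorophenyl in place of 2,4-dichlorophenyl on an aromatic nitrogen). The measured steps that bear on it are those between the groups on the aromatic nitrogen: an at least 1.3-fold lower number from compound 1 to compound 2 (0.13 log units; that floor lies within the scatter) and an at least 1.3-fold higher number from compound 2 to compound 3 (0.13 log units; that floor lies within the scatter), both of them floors that lie within the scatter. Phenyl in compound 1 and 2,4-dichlorophenyl in compound 3 each fail to give a number, while 4-methoxyphenyl in compound 2 gives 7400 nM. A 4-fluorophenyl is expected to behave like those neighbours, so the step that the limit leaves unreadable from compound 3 to compound 4 is expected to stay within the scatter. Compound 4 is therefore estimated at 12000 nM, with a range from 5000 nM to 30000 nM, and is expected more often than not to be reported only as a limit.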

Compound 4, half-maximal inhibitory concentration: > 10000 nM
Compound 4: no number, only a limit; the forecaster's own chance of this, stated with the estimate: 60%; the middle value does not contradict the limit.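

In this assay, compound 4 also returns only a limit, so the 4-fluorophenyl on the aromatic nitrogen yields no number, like the phenyl of compound 1 and the 2,4-dichlorophenyl of compound 3: the limit of > 10000 nM in this assay, at which 3 of the 4 values shown sit.

Against compound 2, the only compound here with a number, fluoro in place of methoxy gives an at least 1.3-fold higher number from compound 2 to compound 4 (0.13 log units; that floor lies within the scatter), so the two groups are not separated on this read-out. The steps from compound 3 to compound 4 and from compound 1 to compound 4 join limit to limit and cannot be read.

Going by these compounds, it remains open whether any group on this aromatic nitrogen can bring the series clearly under the limit. A 4-ethoxyphenyl, with its longer chain, or a 4-dimethylaminophenyl in this place would test whether the measurable value of compound 2 marks a real trend.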